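This account rests on a few compounds, and the source may have more. Where it says the series, first, only, none or still open, it means among the compounds named here.

Measured in an assay on L1.2 cells for binding affinity to C-C chemokine receptor type 8 (Homo sapiens); a lower number here means a stronger inhibitor, a higher number a weaker inhibitor:
Compound 1, `CC(=O)N1CCC(NS(=O)(=O)c2ccc(NC(=O)c3ccccc3C)c3ccccc23)CC1`, gives 6.7 nM.
Compound 2, `Cc1ccccc1C(=O)Nc1ccc(S(=O)(=O)NC2CCN(C(=O)NC(C)C)CC2)c2ccccc12`, gives 77.7 nM.
Compound 3, `Cc1ccccc1C(=O)Nc1ccc(S(=O)(=O)NC2CCN(C(=O)N3CCC3)CC2)c2ccccc12`, gives 3.5 nM.

Among these three numbers compound 1 stands second highest, nearest to compound 3 and furthest from compound 2. Compound 4, `Cc1ccccc1C(=O)Nc1ccc(S(=O)(=O)NC2CCN(C(=O)N3CCOCC3)CC2)c2ccccc12`, has not yet been measured in this assay. It differs from compound 1 in one place: morpholin-4-yl in place of methyl on a carbonyl carbon. Two measured steps start from the same place on compound 1: the change to isopropylamino gave a 12-fold higher number from compound 1 to compound 2 (1.06 log units; beyond the scatter), while the change to azetidin-1-yl gave a 1.9-fold lower number from compound 1 to compound 3 (0.28 log units; within the scatter). Morpholin-4-yl, like azetidin-1-yl, is a ring with no hydrogen-bond donor, so in this assay only a step close to the scatter is expected, a 1.2-fold higher number from compound 1 to compound 4 (0.08 log units; within the scatter). Compound 4 is therefore estimated at 8 nM, within 3 nM to 25 nM.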

Compound 4, inhibition constant: 6.3 nM
Beside the measured number, compound 4's estimate is 1.3-fold (0.10 log units) above it; the measured number falls inside the stated range.
By their numbers in this assay, from the lowest: compounds 3, 4 and 1 (each within the scatter of the next); then compound 2.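

In this assay, morpholin-4-yl on this carbonyl carbon gives a 1.1-fold lower number from compound 1 to compound 4 (0.03 log units; within the scatter) and a 1.8-fold higher number from compound 3 to compound 4 (0.26 log units; within the scatter), so methyl, azetidin-1-yl and morpholin-4-yl cannot be told apart here. A larger six-membered ring carrying an oxygen therefore stays within the scatter of the two smaller groups, while isopropylamino alone stands apart, with a 12-fold lower number from compound 2 to compound 4 (1.09 log units; beyond the scatter). Nothing measured here gives a reason for that gap. 

On these data alone, it remains open whether the weaker number of compound 2 goes with the hydrogen on the nitrogen of isopropylamino or with its branched carbons. Dimethylamino, with carbons on that nitrogen but no such hydrogen, would help separate the two.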